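This account rests on a few compounds, and the source may have more. Where it says the series, first, only, none or still open, it means among the compounds named here.

For the measured compounds named here, compound 3, with the structure `COc1cc(C(=O)O)cc2c1C[C@@](C)(C1CC=C(C)CC1)O2`, is one of three compounds measured so far. In a functional assay on the whole organism for inhibition, with Homo sapiens as the target, read by hemolysis (on this read-out lower numbers stand for stronger inhibition and higher numbers for weaker inhibition), compound 3 gives > 1000000 nM, which is a limit of the assay rather than a number. Compound 1, with the structure `CC1=CCC([C@]2(C)Cc3c(O)cc(C(=O)O)cc3O2)CC1`, gives 730000 nM in this assay. Compound 2, with the structure `CC1=CCC([C@]2(C)Cc3c(Oc4ccccc4)cc(C=O)cc3O2)CC1`, gives > 862000 nM in this assay, again a limit. Going by the values given here, the one measured step bearing on the series is an at least 1.3-fold higher number from compound 1 to compound 3 (0.13 log units; that floor lies within the scatter). Compound 4, with the structure `CC1=CCC([C@]2(C)Cc3c(Oc4ccccc4)cc(C(=O)O)cc3O2)CC1`, differs from compound 3 by phenyl in place of methyl on an oxygen on an aromatic ring. Among the compounds with values here, no measured step covers this exchange, and compound 2, which carries a phenoxy group, sits at the limit of > 862000 nM in this assay, at which 1 of the 3 values shown sits. For compound 4 the expected step is a number no higher from compound 3 to compound 4 (the limit leaves the size open), and the estimate is 1000000 nM, with a range from 500000 nM to 3000000 nM.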

Compound 4, half-maximal inhibitory concentration: > 824000 nM
Compound 4 ended at the assay's limit (the forecaster's own chance of this, stated with the estimate: 85%); the middle value does not contradict the limit.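

With phenoxy in place of methoxy on an oxygen on an aromatic ring, compound 4 also stays at a limit of the assay in this assay: the limit of > 824000 nM in this assay, at which 1 of the 4 values shown sits. Neither group therefore gives a readable number here, and the steps from compound 3 and compound 2 to compound 4 cannot be read. For the compounds shown here, the only readable comparison is an at least 1.1-fold higher number from compound 1 to compound 4 (0.05 log units; that floor lies within the scatter).

As far as these compounds go, how large that step really is stays open, since only its floor is known. From the compounds shown here alone, whether a longer chain such as butyl, or an amine, on this oxygen would give a measurable number also stays open.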